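The source may report more compounds than this note shows. Statements on the series, on what has been measured and on what is new or still open speak of the compounds shown alone.

In an ADME assay on HepG2 2.2.15 cells (Homo sapiens) for cytotoxicity (on this read-out higher numbers stand for lower toxicity in this test and lower numbers for higher toxicity in this test), compound 1 (`CCCC(=O)OCCc1c(-c2ccccc2Cl)c2cc(Cl)ccc2[nH]c1=O`) gives 52000 nM and compound 2 (`CC(=O)OCC(=O)OCCc1c(-c2ccccc2Cl)c2cc(Cl)ccc2[nH]c1=O`) gives 100000 nM while compound 3 (`O=C(/C=C/c1ccccc1)OCCc1c(-c2ccccc2Cl)c2cc(Cl)ccc2[nH]c1=O`) gives 230000 nM as the highest number of the three. Compound 4 (`O=C(/C=C/c1ccc(C(F)(F)F)cc1)OCCc1c(-c2ccccc2Cl)c2cc(Cl)ccc2[nH]c1=O`) differs from compound 3 by one change (trifluoromethyl in place of hydrogen on an aromatic carbon) with trifluoromethyl in place of hydrogen on an aromatic carbon. Going by the values given here, no measured step makes this change. The nearest steps brought in 2-phenylethenyl on a carbonyl carbon (a 4.4-fold higher number from compound 1 to compound 3 (0.65 log units; beyond the scatter) and a 2.3-fold higher number from compound 2 to compound 3 (0.36 log units; beyond the scatter)) and both were modest. These steps swap whole groups, so they are only a rough guide, and a small downward step or none beyond the scatter is expected. That means an expected 1.4-fold lower number from compound 3 to compound 4 (0.13 log units; within the scatter) on this estimate. In this assay compound 4 is expected at 170000 nM (estimated range 60000 nM to 400000 nM).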

Compound 4, half-maximal cytotoxic concentration: > 1400000 nM
Compound 4: only a limit was reported (the forecaster's own chance of this, stated with the estimate: 15%); middle value at least 8.2-fold (0.91 log units) from the limit.
By their numbers in this assay, from the lowest: compounds 1 and 2 (each within the scatter of the next); then compound 3. At a limit, above all of these: compound 4.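

Compound 4 gives only a limit in this assay, not a number: the limit of > 1400000 nM in this assay, at which 1 of the 4 values shown sits. The earlier steps shown here changed the whole group on the carbonyl carbon, whereas replacing a single hydrogen on the aromatic ring with trifluoromethyl gives an at least 6.0-fold higher number from compound 3 to compound 4 (0.78 log units; beyond the scatter). With the whole group swapped, the steps are an at least 14-fold higher number from compound 2 to compound 4 (1.14 log units; beyond the scatter) and an at least 26-fold higher number from compound 1 to compound 4 (1.43 log units; beyond the scatter), both larger than any earlier step.

From the compounds shown here alone, how far the true number for compound 4 lies past the limit stays unknown. Going by these compounds, what a fluorine atom, a methoxy group or an amine on the same aromatic carbon would give also remains open.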